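This account rests on a few compounds, and the source may have more. Where it says the series, first, only, none or still open, it means among the compounds named here.

Measured in a functional assay on OCI-Ly3 cells (Homo sapiens) for inhibition, read by CellTiter-Glo, with stated times of 48 h and 96 h; a lower number here means a stronger inhibitor of growth, a higher number a weaker inhibitor of growth:
Compound 1 `CC(C)[C@@H](C(=O)N1CCC[C@H]1C(=O)N[C@@H](CCCNC(=N)N)C(=O)CF)N(C)C(=O)OCc1ccccc1`: > 20000 nM (a limit of the assay, not a number)
Compound 2 `CC(C)[C@H](NC(=O)c1ccccc1)C(=O)N1CCC[C@H]1C(=O)N[C@@H](CCCNC(=N)N)C(=O)CF`: 660 nM

Going by the values given here, compound 2 holds the only actual number so far. Compound 3 `CC(C)[C@H](NC(=O)c1ccccc1Br)C(=O)N1CCC[C@H]1C(=O)N[C@@H](CCCNC(=N)N)C(=O)CF` differs from it by bromo in place of hydrogen on an aromatic carbon, ortho to a large group. Among the compounds with values here, the one measured step, an at least 30-fold lower number from compound 1 to compound 2 (1.48 log units; beyond the scatter), is large and brings in the benzamido group, but it involves no bromo and so bears only loosely. No step beyond the scatter is therefore expected in this assay, and no direction can be favoured. The expected change is a 1.1-fold lower number from compound 2 to compound 3 (0.04 log units; within the scatter). Compound 3 is estimated at 600 nM, with an expected range of 170 nM to 2400 nM.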

Compound 3, concentration for 50% growth inhibition: 4240 nM
For compound 3 the middle estimate is 7.1-fold (0.85 log units) below the measured one; the whole stated range lies below it.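

In this assay, bromo on an aromatic carbon, ortho to a large group, does not leave the benzamido series unchanged: the result is a 6.4-fold higher number from compound 2 to compound 3 (0.81 log units; beyond the scatter). Going by these compounds alone, this is the first sign that this ring position responds to substitution, and here the change weakens growth inhibition. The ((2-bromophenyl)carbonyl)amino group still compares well with the group in compound 1, with an at least 4.7-fold lower number from compound 1 to compound 3 (0.67 log units; beyond the scatter), but that step is only a bound: the limit of > 20000 nM in this assay, at which 1 of the 3 values shown sits.

Going by these compounds, whether the loss is specific to bromo remains open. So does how a fluoro, methoxy or amine group would behave at this position or elsewhere on the ring.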